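A few compounds are considered here, and "the series" means these few. Any claim that something is new, unique, unknown or untested is made for them only; others in the source may bear on it.

Measured compounds:
Compound 1, `CCCSc1nc(Cl)c2c(n1)N(Cc1cccs1)C(C(=O)N1CCN(C)CC1)N2`: 5020 nM
Compound 2, `CCCSc1nc(Cl)c2c(n1)N(Cc1ccccc1)C(C(=O)OCC)N2`: 62500 nM

Both were tested in a functional assay on PC-3 cells (Homo sapiens) for antiproliferative activity, read by MTT assay, with a stated time of 72 h; a lower number here means a stronger inhibitor, a higher number a weaker inhibitor. Compound 2 stands at the higher of the two numbers with 62500 nM, while compound 1 reaches 5020 nM, a gap beyond the usual scatter; the two differ in more than one place, so this gap cannot be tied to any single change. Compound 3, `CCCSc1nc(Cl)c2c(n1)N(Cc1ccccc1)C(C(=O)NCCNC(=O)OC(C)(C)C)N2`, is not yet measured. It differs from compound 2 in one place: (2-((tert-butoxycarbonyl)amino)ethyl)amino in place of ethoxy on a carbonyl carbon. Compound 1 also bears a nitrogen rather than the ethoxy on its carbonyl carbon, and its value of 5020 nM is the only hint available. On that basis the step is expected to lower the number moderately, a 3.1-fold lower number from compound 2 to compound 3 (0.49 log units; beyond the scatter), with wide uncertainty. Compound 3 is therefore estimated at 20000 nM, within a range from 6000 nM to 60000 nM.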

Compound 3, half-maximal inhibitory concentration: 29700 nM
Estimate against measurement, compound 3: 1.5-fold (0.17 log units) below; measured number inside the range.
By their numbers in this assay, from the lowest: compound 1; then compound 3; then compound 2.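

In this assay, the carbonyl carbon attached to the saturated ring carbon tolerates a much larger group than ethoxy: placing (2-((tert-butoxycarbonyl)amino)ethyl)amino there gives a 2.1-fold lower number from compound 2 to compound 3 (0.32 log units; beyond the scatter). Among the compounds shown here, this is the first comparison at this position in which only one place changes, so this shift can be tied to this single swap. No measurement shown here explains the step.

Going by these compounds, what stays open is which part of the new group carries the step: the nitrogen on the carbonyl, the ethyl chain or the tert-butoxycarbonyl end. A simple methylamine on the carbonyl, a free primary amine at the end of the same chain, or a longer chain between the two nitrogens would help separate these parts.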